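This account rests on a few compounds, and the source may have more. Where it says the series, first, only, none or still open, it means among the compounds named here.

Compound 1 `CC1=C(C(=O)Nc2ccc([N+](=O)[O-])cc2)C(c2ccc(Br)cc2)N=C(SCc2ccccc2)N1` gives 37.6% in a functional assay on the whole organism (artery, strain albino) with Rattus norvegicus as the target, with a stated time of 360 min, at a dose of 10 mg/kg by the oral route; a higher number here means more inhibition at the dose given (going by the name of the read-out), a lower number less inhibition. Of the three measured compounds, compound 3 `CC1=C(C(=O)Nc2ccc([N+](=O)[O-])cc2)C(c2ccc(Br)cc2)N=C(SCc2ccc(Cl)cc2)N1` gives 39.2%, a step of a number 1.6 percentage points higher from compound 1 to compound 3 (within the scatter), so the two cannot be ordered, while compound 2 `CC1=C(C(=O)Nc2ccc([N+](=O)[O-])cc2)C(c2ccc(Br)cc2)N=C(SCc2ccccc2Cl)N1` gives 13.9%, a step of a number 23.7 percentage points lower from compound 1 to compound 2 (beyond the scatter). Compound 4 `CC1=C(C(=O)Nc2ccc([N+](=O)[O-])cc2)C(c2cccc([N+](=O)[O-])c2)N=C(SCc2ccccc2)N1` differs from compound 1 by 3-nitrophenyl in place of 4-bromophenyl on a saturated ring carbon. Within the data shown here, the measured steps all concern chloro on the benzylsulfanyl group; none alters the saturated ring carbon, so no step bears directly on this change, and the size and direction of its effect cannot be read from the series. Compound 4 is therefore expected to give a value near that of compound 1, a step of a number 2.6 percentage points lower from compound 1 to compound 4 (within the scatter), with a wide range. The estimate for compound 4 is 35%, between 10% and 60%.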

Compound 4, a percentage reported as inhibition, in the whole organism at one dose (the size of the read-out at that dose, not a potency): 32.5%
Compound 4: middle estimate off by 2.5 percentage points, on the high side; the range from low to high includes it.
By their numbers in this assay, from the lowest: compound 2; then compounds 4, 1 and 3 (each within the scatter of the next).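

Among these compounds, on the saturated ring carbon, the first change at this position gives, in this assay, a number 5.1 percentage points lower from compound 1 to compound 4 (within the scatter), so 3-nitrophenyl and 4-bromophenyl cannot be ordered there. A change at this position can therefore leave the read-out within the scatter, even with a different substituent at a different place on the phenyl ring. Nothing available explains this result.

Open, on these data alone, is whether the same holds for other groups on this carbon, such as an unsubstituted phenyl, a 4-aminophenyl or a 4-carboxyphenyl. The effects of the substituent and of its place on the phenyl ring also remain unseparated.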